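The source may hold more compounds than are shown below. What is called first, only, known or untested is meant among the compounds shown, and "the series" means these compounds.

Measured compounds:
Compound 1 `Cc1ccc(S(=O)(=O)N2CCN(CCCn3c(=O)[nH]c4ccccc43)CC2)cc1` gives > 10000 nM in an assay on RPMI-8226 cells for antagonist activity at P2X purinoceptor 7 (Homo sapiens), read by calcium flux (on this read-out higher numbers stand for weaker inhibition and lower numbers for stronger inhibition), which is a limit of the assay rather than a number, as recorded in the limit of > 10000 nM in this assay, at which 1 of the 3 values shown sits.
Compound 2 `O=c1[nH]c2ccccc2n1CCCN1CCC(C(O)(c2ccccc2)c2ccccc2)CC1` gives 7500 nM in this assay.
Compound 3 `O=c1[nH]c2ccccc2n1CCCCN1CCN(C(c2ccccc2)c2ccccc2)CC1` gives 180 nM in this assay.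

Compound 3 carries the lowest number of the two numbers shown. Its nearest neighbour among numbered values is compound 2, whose value sits well beyond the scatter above it; the remaining value, that of compound 1, is a limit and cannot be placed in order. Within the data shown here, no two measured compounds differ in just one place, so no single step has been isolated.

Compound 4 `O=c1[nH]c2ccccc2n1CCCCCN1CCN(C(c2ccccc2)c2ccccc2)CC1` is not yet measured. It differs from compound 3 by a group of 11 heavy atoms (8 carbon, 2 nitrogen, 1 oxygen; one five-membered aromatic ring with 2 hetero atoms, one six-membered aromatic ring of carbon only) in place of a group of 10 heavy atoms (7 carbon, 2 nitrogen, 1 oxygen; one five-membered aromatic ring with 2 hetero atoms, one six-membered aromatic ring of carbon only), on a saturated chain carbon, four bonds along the chain from an amine nitrogen in a ring, which is a lengthening of the saturated chain by one carbon. Among the measured compounds shown here, no measured pair shows what such a lengthening alone does here. The expectation is therefore a step of modest size from compound 3 to compound 4, with a slight lean towards a higher number, well within or only marginally beyond the scatter: a 1.4-fold higher number from compound 3 to compound 4 (0.14 log units; within the scatter). Compound 4 is estimated at 250 nM in this assay, with a range from 80 nM to 800 nM.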

Compound 4, half-maximal inhibitory concentration: 560 nM
Estimate against measurement, compound 4: 2.2-fold (0.35 log units) below; the range from low to high includes it.
By their numbers in this assay, from the lowest: compound 3; then compound 4; then compound 2. At a limit, above all of these: compound 1.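

In this assay, lengthening the saturated chain by one carbon gives a 3.1-fold higher number from compound 3 to compound 4 (0.49 log units; beyond the scatter), a modest step but one beyond the scatter. Among these compounds, this is the first change read in isolation: the place four bonds along the chain from the amine nitrogen in a ring responds to chain length when the rest of the structure is held constant, and of these two chain lengths the shorter one, in compound 3, gives the lower number. No measurement shown gives a cause for this step.

Going by these compounds, one step cannot show a trend, so it remains open whether a shorter chain than that of compound 3 would lower the number further or raise it, and whether a longer chain than that of compound 4 would continue the rise. On these data alone, compound 1 and compound 2 differ from compound 3 in more than one place, so the effect of chain length with those other end groups is unknown, as is the effect of a hydroxyl group or an amine placed on the chain itself.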